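Removing an Acetyl Group from a Natural-Product-Like Scaffold

The source may report more compounds than this note shows. Statements on the series, on what has been measured and on what is new or still open speak of the compounds shown alone.

Measured compounds:
Compound 1, `CCc1oc([C@H](C)/C=C(\C)[C@H](OC(C)=O)[C@H](C)[C@@H](OC(=O)CC(C)C)[C@@H](C)c2oc([C@@H](C)[C@@H](O)CC)c(C)c(=O)c2C)c(C)c(=O)c1C`: 15000 nM
Compound 2, `CCc1oc([C@H](C)/C=C(\C)[C@H](OC(C)=O)[C@H](C)[C@@H](OC(=O)CC(C)C)[C@@H](C)c2oc([C@@H](C)[C@H](CC)OC(C)=O)c(C)c(=O)c2C)c(C)c(=O)c1C`: 28000 nM

Both compounds were tested in a functional assay on A549 cells (Homo sapiens) for inhibition, read by MTT assay, with a stated time of 72 h; on this read-out lower numbers stand for stronger inhibition and higher numbers for weaker inhibition. Compound 1 gives 15000 nM, the lowest of the two numbers, and compound 2 gives 28000 nM; the two lie within the scatter of each other. For the measured compounds named here, the single measured step, a 1.9-fold higher number from compound 1 to compound 2 (0.27 log units; within the scatter), arose from acetyl in place of hydrogen on an oxygen on a saturated carbon and did not move the number beyond the scatter.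

Compound 3, `CCc1oc([C@H](C)/C=C(\C)[C@H](O)[C@H](C)[C@@H](OC(=O)CC(C)C)[C@@H](C)c2oc([C@@H](C)[C@@H](O)CC)c(C)c(=O)c2C)c(C)c(=O)c1C`, is not yet measured. Going by the values given here, it differs from compound 1 by hydrogen in place of acetyl on an oxygen on a saturated carbon, at a different oxygen than the one changed between compound 1 and compound 2. Among the compounds with values here, the only step that bears on it, a 1.9-fold higher number from compound 1 to compound 2 (0.27 log units; within the scatter), involved the same kind of exchange, in the opposite direction, and stayed within the scatter. The step of a 1.2-fold lower number from compound 1 to compound 3 (0.06 log units; within the scatter) is therefore expected to stay within the scatter as well. Compound 3 is estimated at 13000 nM, with a range from 5000 nM to 32000 nM.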

Compound 3, half-maximal inhibitory concentration: > 100000 nM
Compound 3 gave a limit, no number; the forecaster's own chance of this, stated with the estimate: 10%; middle value at least 7.6-fold (0.88 log units) away from the limit.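

Changing acetoxy to hydroxy at this oxygen on a saturated carbon has a clear effect in this assay, giving an at least 6.6-fold higher number from compound 1 to compound 3 (0.82 log units; beyond the scatter). The same kind of exchange at the other oxygen gave a step within the scatter, a 1.9-fold higher number from compound 1 to compound 2 (0.27 log units; within the scatter), so the two oxygens of the shared core do not respond alike in this pair of steps. Compound 3 gives a limit of the assay, not a number: the limit of > 100000 nM in this assay, at which 1 of the 3 values shown sits.

The compounds shown leave open whether the acetyl group is specifically needed at this oxygen, or whether a longer ester such as propanoyl, a methyl ether or an amine in its place would keep the value close to that of compound 1. From the compounds shown here alone, they also leave open how far the number for compound 3 lies beyond the limit, so the full size of this step remains unknown.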